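The source may hold more compounds than are shown below. What is called first, only, known or untested is meant among the compounds shown, and "the series" means these compounds.

Compound 1 `Cn1c(-c2ccccc2)cnc1NC(=O)c1ccc(F)cc1`. In a toxicity assay on THP-1 cells (Homo sapiens) for inhibition (a higher number here means that more compound is tolerated, a lower number that less compound is tolerated), compound 1 gives > 100000 nM, which is a limit of the assay and not a number.
Compound 2 `Cc1ccc(C(=O)Nc2ncc(-c3ccccc3)n2C)cc1`. In this assay compound 2 gives > 50000 nM, again a limit.
Compound 3 `COc1ccc(-c2cnc(NC(=O)c3ccccc3C)n2C)cc1`. In this assay compound 3 gives > 100000 nM, also a limit.

Among the measured compounds shown here, all three measured compounds reach only limits, and the same holds for the one change that links two of them. For the measured compounds named here, from compound 2 to compound 1 the change is fluoro in place of methyl on an aromatic carbon and the step is a step that the two limits leave unreadable from compound 2 to compound 1; its size cannot be read because the limit of > 100000 nM in this assay, at which 2 of the 3 values shown sit, and the limit of > 50000 nM in this assay, at which 1 of the 3 values shown sits, are the only things the two values show.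

Compound 4 `COc1ccc(-c2cnc(NC(=O)c3ccccc3F)n2C)cc1` is not yet measured. It differs from compound 3 by fluoro in place of methyl on an aromatic carbon. This is the same kind of change as that from compound 2 to compound 1, though not the same: there the fluoro stands para to a large group, here it stands ortho to a large group. How the core of compound 3 differs from the core of compound 2 is not broken down here.

Compound 3 itself sits at a limit, > 100000 nM, so there is no number from which a step can be built. Compound 4 is therefore expected to be tolerated to a similar degree, with an expected step of a number no higher from compound 3 to compound 4 (the limit leaves the size open), resting on the observation that compound 3 gives > 100000 nM and that the related change from compound 2 to compound 1 left both compounds at limits. The estimate for compound 4 in this assay is 100000 nM, with an expected range from 40000 nM to 300000 nM, and most likely the assay will again report only a limit.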

Compound 4, half-maximal cytotoxic concentration: > 100000 nM
Compound 4: only a limit was reported; the forecaster's own chance of this, stated with the estimate: 80%; the middle value lies on the limit itself.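

Like compound 3, compound 4 reaches only a limit of the assay and not a number, so no step can be read from compound 3 to compound 4, and fluoro in place of methyl remains unsized here. With all four compounds at limits, the compounds shown leave open how much of any of them is tolerated and whether either change alters that tolerance at all.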